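This account rests on a few compounds, and the source may have more. Where it says the series, first, only, none or still open, it means among the compounds named here.

Three compounds from one series share a core, and each carries a different group on an amide carbonyl at the same position. Compound 1, `CCc1nn(CC)c(C2CCN(C(=O)CN3CN(c4ccccc4)C4(CCN(C(=O)c5ccc(C6CCCCC6)cc5)CC4)C3=O)CC2)c1C`, has no reported result in an assay on HEK293 cells for displacement of a labelled ligand from NPC1-like intracellular cholesterol transporter 1 (Homo sapiens) (on this read-out higher numbers stand for weaker inhibition and lower numbers for stronger inhibition), where compound 1 gives "not determined" (no result reported). Compound 2, `CC(C)(C)c1ccc(C(=O)N2CCC3(CC2)C(=O)N(CC(=O)N2CCN(S(C)(=O)=O)CC2)CN3c2ccccc2)cc1`, was tested in this assay, where compound 2 gives 19000 nM. Compound 3, `CC(C)(C)OC(=O)NCCCCNC(=O)CN1CN(c2ccccc2)C2(CCN(C(=O)c3ccc(C4CCCCC4)cc3)CC2)C1=O`, gives 4600 nM in this assay. Compound 2 therefore stands at the higher of the two numbers, and the gap between compound 2 and compound 3 is wider than the usual scatter of repeated measurements, so compound 3 is the stronger inhibitor of the two.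

Compound 4, `CCOC(=O)C1CCN(C(=O)CN2CN(c3ccccc3)C3(CCN(C(=O)c4ccc(C(C)(C)C)cc4)CC3)C2=O)CC1`, has not been measured. Compared with compound 2, the change is 4-(ethoxycarbonyl)piperidin-1-yl in place of 4-(methylsulfonyl)piperazin-1-yl on a carbonyl carbon. Among the measured compounds shown here, no two measured compounds differ from each other in only one place, so no single-change step is available to guide the expectation directly. For the measured compounds named here, the only comparison at hand is that of compound 2 with compound 3, which shows that a different amide group at this carbonyl can lower the number.

On that basis compound 4 is expected to give a somewhat lower number than compound 2, a step of a 2.1-fold lower number from compound 2 to compound 4 (0.32 log units; beyond the scatter) that may not clearly exceed the scatter. The estimate for compound 4 is 9000 nM, with a range from 3000 nM to 30000 nM.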

Compound 4, half-maximal inhibitory concentration: 3100 nM
For compound 4 the middle estimate is 2.9-fold (0.46 log units) above the measured one, and the stated range covers the measured number.
By their numbers in this assay, from the lowest: compounds 4 and 3 (each within the scatter of the next); then compound 2.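

In this assay, among the compounds shown here, putting 4-(ethoxycarbonyl)piperidin-1-yl in place of 4-(methylsulfonyl)piperazin-1-yl on a carbonyl carbon gives a 6.1-fold lower number from compound 2 to compound 4 (0.79 log units; beyond the scatter); this is the first comparison in which only this one group differs, so the shift can be tied to this position and this change. The step does not go with a change in the simple counts, since both groups have 0 hydrogen-bond donors, 2 hydrogen-bond acceptors, no net charge and one six-membered non-aromatic ring, while the entering group has 1 ring hetero atom instead of 2, has no sulfur and has 1 double bond outside aromatic rings instead of 2. No measurement shown here explains the step.

The swap changes the ring and its substituent together, so it remains open which of the two accounts for the lower number; 4-(methylsulfonyl)piperidin-1-yl would keep the sulfonyl group on the new ring and separate the two changes. On these data alone, it is also open whether the ethyl ester itself matters, which a plain piperidin-1-yl group or a piperidine bearing a carboxylic acid at the same ring position could test.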